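From Trifluoromethyl to Fluoro: What Compound 4 Might Give

The source may hold more compounds than are shown below. What is called first, only, known or untested is meant among the compounds shown, and "the series" means these compounds.

Of the compounds shown here, three sharing one core have been tested in a functional assay on HCT-116 cells (Homo sapiens) for cytotoxicity, read by MTT assay, with a stated time of 48 h; a lower number here means a stronger inhibitor, a higher number a weaker inhibitor. Compound 1 `CCN(CC)c1ccc2cc(C(=O)c3ccc(N4CCN(C(=O)CN5CCN(C(=O)/C=C/c6ccccc6)CC5)CC4)cc3)oc2c1` gives 6810 nM, and compound 2 `CCN(CC)c1ccc2cc(C(=O)c3ccc(N4CCN(C(=O)CN5CCN(S(=O)(=O)c6ccc(OC(F)(F)F)cc6)CC5)CC4)cc3)oc2c1` gives 7680 nM. Compound 3 `CCN(CC)c1ccc2cc(C(=O)c3ccc(N4CCN(C(=O)CN5CCN(S(=O)(=O)c6ccc(C(F)(F)F)cc6)CC5)CC4)cc3)oc2c1` gives 32200 nM, the highest of the three numbers, standing beyond the scatter from both compound 2 and compound 1. Within the data shown here, the single step measured between neighbours in this set is a 4.2-fold higher number from compound 2 to compound 3 (0.62 log units; beyond the scatter). Compound 4 `CCN(CC)c1ccc2cc(C(=O)c3ccc(N4CCN(C(=O)CN5CCN(S(=O)(=O)c6ccc(F)cc6)CC5)CC4)cc3)oc2c1` differs from compound 3 by fluoro in place of trifluoromethyl on an aromatic carbon. Among the measured compounds shown here, only that one measured step bears on this change, and in it the trifluoromethyl compound carried the highest number. Compound 4 is therefore expected to come in somewhat lower, by an estimated 2.7-fold lower number from compound 3 to compound 4 (0.43 log units; beyond the scatter). The estimate for compound 4 is 12000 nM, with a range from 4000 nM to 36000 nM.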

Compound 4, half-maximal inhibitory concentration: > 40000 nM
Compound 4: no number, only a limit (the forecaster's own chance of this, stated with the estimate: 10%); at least 3.3-fold (0.52 log units) between middle value and limit.
By their numbers in this assay, from the lowest: compounds 1 and 2 (each within the scatter of the next); then compound 3. At a limit, above all of these: compound 4.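

Compound 4 gives no number, only a limit: the limit of > 40000 nM in this assay, at which 1 of the 4 values shown sits. Fluoro in place of trifluoromethyl on this aromatic carbon gives an at least 1.2-fold higher number from compound 3 to compound 4 (0.09 log units; that floor lies within the scatter), so fluoro brings no lower number here, yet the true size of this step stays unknown. The clearer contrasts are with trifluoromethoxy, an at least 5.2-fold higher number from compound 2 to compound 4 (0.71 log units; beyond the scatter), and with the (2-phenylethenyl)carbonyl group on the ring nitrogen, an at least 5.8-fold higher number from compound 1 to compound 4 (0.76 log units; beyond the scatter).

Still open, as far as these compounds go, is how a methoxy group, an amine or a carboxylic acid on this aromatic carbon would compare. With so few groups shown, no trend across this position can be drawn.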